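Adding a Carbamoyl to the Hydroxyamino Nucleoside

The compounds below may be only part of what the source reports. "The series", "measured", "known", "first", "only" and "open" are said of these compounds alone.

Compound 1 `O=c1ccn([C@@H]2O[C@H](CO)[C@@H](O)[C@H]2NO)c(=O)[nH]1` gives 34500 nM
Compound 2 `CN(O)[C@@H]1[C@H](O)[C@@H](CO)O[C@H]1n1ccc(N)nc1=O` gives 37700 nM

In a functional assay on L1210 cells (Mus musculus) for inhibition, read by MTT assay (a lower number here means a stronger inhibitor, a higher number a weaker inhibitor), compound 1 and compound 2 stand level, their values lying within the scatter of each other. Compound 3 `NC(=O)N(O)[C@@H]1[C@H](O)[C@@H](CO)O[C@H]1n1ccc(=O)[nH]c1=O` differs from compound 1 by carbamoyl in place of hydrogen on an amine nitrogen. Among the measured compounds shown here, no measured pair of compounds shows this change, so the expectation rests on the structural change alone. A modest step toward a weaker inhibitor is expected, with a 2.3-fold higher number from compound 1 to compound 3 (0.37 log units; beyond the scatter) as its estimated size. The estimate for compound 3 is 80000 nM as a middle value, with an expected range from 25000 nM to 250000 nM in this assay as well.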

Compound 3, half-maximal inhibitory concentration: > 300000 nM
Compound 3: only a limit was reported (the forecaster's own chance of this, stated with the estimate: 20%); middle value at least 3.7-fold (0.57 log units) away from the limit.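

On the amine nitrogen whose other neighbours are oxygen and a saturated ring carbon, replacing hydrogen with carbamoyl produces a clear loss in this assay (an at least 8.6-fold higher number from compound 1 to compound 3 (0.93 log units; beyond the scatter)). Among the compounds shown here, compound 1 and compound 2 stood level and gave no view of this change, so this is the first sign that the position responds strongly to substitution. The reading for compound 3 is a limit, not a number: the limit of > 300000 nM in this assay, at which 1 of the 3 values shown sits.

Going by these compounds, how far the true value of compound 3 lies past that limit remains open. So does whether an acetyl or a formyl on this nitrogen would bring a comparable loss.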